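This account rests on a few compounds, and the source may have more. Where it says the series, first, only, none or still open, it means among the compounds named here.

Working notes on the hydroxamate series. Compound 1 `CC[C@H]1OC(=O)[C@H](C)C(=O)[C@H](C)[C@@H](O[C@@H]2O[C@H](C)C[C@H](N(C)Cc3ccc(-c4cn(CC(=O)NO)nn4)cc3)[C@H]2O)[C@@](C)(OC)C[C@@H](C)C2=NCCN3C(=O)O[C@@]1(C)[C@H]3[C@H]2C` gives 2850 nM in an assay for inhibition of histone deacetylase 8 (Homo sapiens), read by mass spectrometry, with a stated time of 60 min; on this read-out higher numbers stand for weaker inhibition and lower numbers for stronger inhibition. Compound 2 `CC[C@H]1OC(=O)[C@H](C)C(=O)[C@H](C)[C@@H](O[C@@H]2O[C@H](C)C[C@H](N(C)Cc3ccc(-c4cn(CCC(=O)NO)nn4)cc3)[C@H]2O)[C@@](C)(OC)C[C@@H](C)C2=NCCN3C(=O)O[C@@]1(C)[C@H]3[C@H]2C` returns only a limit in this assay, > 10000 nM. Compound 3 `CC[C@H]1OC(=O)[C@H](C)C(=O)[C@H](C)[C@@H](O[C@@H]2O[C@H](C)C[C@H](N(C)Cc3ccc(-c4cn(CCCC(=O)NO)nn4)cc3)[C@H]2O)[C@@](C)(OC)C[C@@H](C)C2=NCCN3C(=O)O[C@@]1(C)[C@H]3[C@H]2C` gives 2240 nM in this assay, the lower of the two numbers shown, though the gap to compound 1, a 1.3-fold lower number from compound 1 to compound 3 (0.10 log units; within the scatter), does not separate the two. Compound 4 `CC[C@H]1OC(=O)[C@H](C)C(=O)[C@H](C)[C@@H](O[C@@H]2O[C@H](C)C[C@H](N(C)Cc3ccc(-c4cn(CCCCC(=O)NO)nn4)cc3)[C@H]2O)[C@@](C)(OC)C[C@@H](C)C2=NCCN3C(=O)O[C@@]1(C)[C@H]3[C@H]2C` has not been measured; it differs from compound 3 by (hydroxycarbamoyl)methyl in place of hydroxycarbamoyl on a saturated chain carbon, three bonds along the chain from an aromatic nitrogen. Two measured steps of the same kind bear on this one: an at least 3.5-fold higher number from compound 1 to compound 2 (0.54 log units; beyond the scatter), and then an at least 4.4-fold lower number from compound 2 to compound 3 (0.64 log units; beyond the scatter). Both run beyond the scatter but in opposite directions, the first ending at the limit of > 10000 nM in this assay, at which 1 of the 3 values shown sits, and the second leaving it again. Across the three measured compounds the chain length therefore sets no steady direction: compound 2 stands against any trend of lengthening toward stronger inhibition, and compound 3 against any trend toward weaker. For compound 4 the expected step is a 1.3-fold higher number from compound 3 to compound 4 (0.13 log units; within the scatter), nothing beyond the scatter in either direction. Compound 4 is estimated at 3000 nM in this assay, within 1000 nM to 10000 nM, with some chance that only a limit is returned.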

Compound 4, half-maximal inhibitory concentration: 3210 nM
The estimate for compound 4 lay 1.1-fold (0.03 log units) below the measured number; the range from low to high includes it.
By their numbers in this assay, from the lowest: compounds 3, 1 and 4 (each within the scatter of the next). At a limit, above all of these: compound 2.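

In this assay, the change from 3-(hydroxycarbamoyl)propyl to 4-(hydroxycarbamoyl)butyl gives a 1.4-fold higher number from compound 3 to compound 4 (0.16 log units; within the scatter), and the comparison with the shortest chain gives a 1.1-fold higher number from compound 1 to compound 4 (0.05 log units; within the scatter), so the longest chain shown separates from neither compound. Compound 2 remains the exception, with only a limit of > 10000 nM. The step of an at least 3.1-fold lower number from compound 2 to compound 4 (0.49 log units; beyond the scatter) shows a second chain length, after that of compound 3, standing clear of this limit, which leaves three compounds within the scatter of one another and compound 2 apart from them, while the size of the same change on the two cores stays unresolved: the same change on two cores in this assay, a 1.3-fold lower number (0.10 log units; within the scatter) from compound 1 to compound 3 and an at least 3.1-fold lower number (0.49 log units; beyond the scatter) from compound 2 to compound 4; the limit leaves it open whether they differ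

The compounds shown leave open what number compound 2 would give, and so the full size of every step that touches it. They also leave open whether a longer chain than 4-(hydroxycarbamoyl)butyl, or a carboxylic acid in place of the hydroxycarbamoyl end, would shift the number in this assay beyond the scatter.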